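A few compounds are considered here, and "the series" means these few. Any claim that something is new, unique, unknown or untested is made for them only; others in the source may bear on it.

Compound 1 `CN(CCCn1ccnc1)C(=O)[C@@H]1CCCN1c1nccc(Nc2ccccc2)n1` gives 11% in an assay on isolated protein for inhibition of high affinity nerve growth factor receptor (Homo sapiens), read by HTRF, tested at 10 uM; a lower number here means less inhibition, a higher number more inhibition at the concentration tested (going by the name of the read-out).
Compound 2 `COC[C@@H]1CCCN1C(=O)[C@@H]1CCCN1c1cc(Nc2cccc(OC)c2)nc(N)n1` gives 9% in this assay.
Compound 3 `Cc1cccc(N(C)c2cc(Nc3cccc(C(=O)N4CCCC5CCCCC54)c3)ncn2)c1` gives 12% in this assay.

Among these three numbers compound 3 stands highest, yet the gap to compound 1, its nearest neighbour, and the gap to compound 2, its furthest, both lie within the usual scatter of repeated measurements, so the three compounds cannot be told apart in this assay. All three sit at the low end of the inhibition scale at the concentration tested. Going by the values given here, no pair of measured compounds differs in a single place, so there is no measured step to lean on.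

Among the compounds with values here, compound 4 `Cc1cccc(N(C)c2cc(Nc3cccc(C(=O)N(CC(C)C)CC(C)C)c3)ncn2)c1` is the only new compound. It differs from compound 3 at the carbonyl carbon whose other neighbours are an aromatic carbon: a group of 9 heavy atoms (8 carbon, 1 nitrogen; no ring) in place of a group of 10 heavy atoms (9 carbon, 1 nitrogen; one six-membered non-aromatic ring of carbon only, one six-membered non-aromatic ring with 1 hetero atom), on a carbonyl carbon. The rest of the molecule, including the shared core of compound 3, is kept.

Given that compound 1, compound 2 and compound 3 all show weak inhibition in this assay, the step of a number 1 percentage points lower from compound 3 to compound 4 (within the scatter) is expected to be none beyond the scatter. Compound 4 is therefore estimated to give 11% in this assay, with a range from 0% to 25%.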

Compound 4, a percentage reported as inhibition, at one concentration (the size of the read-out at that concentration, not a potency): 9%
The estimate for compound 4 lay 2 percentage points above the measured number; the measured number falls inside the stated range.
By their numbers in this assay, from the lowest: compounds 2, 4, 1 and 3 (each within the scatter of the next).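

Going by these compounds alone, at the carbonyl carbon whose other neighbours are an aromatic carbon, putting diisobutylamino in place of the group with two six-membered non-aromatic rings gives a number 3 percentage points lower from compound 3 to compound 4 (within the scatter) in this assay, the first step in this set that changes one place only. In this one pair, then, both rings can be given up for an open group with no ring without the number leaving the scatter, and the two compounds cannot be told apart at the concentration tested. Nothing at hand bears on why the reading stays where it does.

Both compounds sit at the low end of the scale, so a single step within the scatter does not settle whether a change at this position can move the number at all. As far as these compounds go, it remains open whether a small group such as dimethylamino, a piperazine or a group carrying a carboxylic acid on the same carbonyl carbon would give a number beyond the scatter from that of compound 3, and how any change to the shared core would read.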